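Shifting a Trifluoromethyl Group in Two Related Series

A few compounds are considered here, and "the series" means these few. Any claim that something is new, unique, unknown or untested is made for them only; others in the source may bear on it.

The set holds three measured compounds and one still to be measured. Compound 1 `Oc1cccc(-c2cc(-c3cccc(C(F)(F)F)c3)cc(-c3cccc(O)c3)n2)c1` and compound 2 `Oc1cccc(-c2cc(-c3ccc(C(F)(F)F)cc3)cc(-c3cccc(O)c3)n2)c1` share one core, while compound 3 `Oc1ccc(-c2cc(-c3cccc(C(F)(F)F)c3)cc(-c3ccc(O)cc3)n2)cc1` and compound 4 `Oc1ccc(-c2cc(-c3ccc(C(F)(F)F)cc3)cc(-c3ccc(O)cc3)n2)cc1` share another; the difference between the two cores is not broken down here.

In a functional assay on HeLa cells (Homo sapiens) for inhibition (a higher number here means a weaker inhibitor, a lower number a stronger inhibitor), compound 1 gives 12700 nM. Compound 2 reaches only > 50000 nM in this assay, which is a limit of the assay and not a number. Compound 3 likewise reaches only > 50000 nM in this assay, again a limit rather than a number.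

The change from compound 1 to compound 2 is 4-(trifluoromethyl)phenyl in place of 3-(trifluoromethyl)phenyl on an aromatic carbon, and it gives an at least 3.9-fold higher number from compound 1 to compound 2 (0.59 log units; beyond the scatter). The change from compound 3 to compound 4 is 4-(trifluoromethyl)phenyl in place of 3-(trifluoromethyl)phenyl on an aromatic carbon. The two are the same kind of change, not the same: around the place, the first sits meta to two 3-hydroxyphenyl groups, the second meta to two 4-hydroxyphenyl groups.

For compound 4 the expectation rests on two facts. Compound 3 already stands at > 50000 nM, a limit. The same kind of change gave an at least 3.9-fold higher number from compound 1 to compound 2 (0.59 log units; beyond the scatter), a weakening. Compound 4 is therefore expected at 150000 nM, within 50000 nM to 600000 nM. That estimate implies a step that the limit leaves unreadable from compound 3 to compound 4, a step expected rather than measured. Because (the limit of > 50000 nM in this assay, at which 2 of the 3 values shown sit), a further limit rather than a number is the most likely report for compound 4.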

Compound 4, half-maximal inhibitory concentration: > 50000 nM
Compound 4: no number, only a limit; the forecaster's own chance of this, stated with the estimate: 90%; the middle value is on the limit's open side.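

In this assay compound 4 gives > 50000 nM, a limit and not a number. Compound 3 also stands at a limit, so no step can be read between compound 3 and compound 4. The compounds shown leave open whether 4-(trifluoromethyl)phenyl in place of 3-(trifluoromethyl)phenyl changes inhibition at all on the core of compound 3, since neither compound has a readable number.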